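Formyl for methoxy on the aryl arm of compound 3

The compounds below may be only part of what the source reports. "The series", "measured", "known", "first", "only" and "open" are said of these compounds alone.

Three compounds of the series have numbers in a physicochemical assay, read by spectrophotometry, with a stated time of 20 min, tested at 100 uM; a lower number here means less inhibition, a higher number more inhibition at the concentration tested (going by the name of the read-out). Compound 1 `O=c1oc2ccc(Br)cc2cc1-c1ccc(O)c(O)c1` gives 78% in this assay. Compound 2 `COc1ccc(-c2c(C)c3ccccc3o/c2=N/Nc2ccccc2)cc1` gives 84%. Compound 3 `COc1ccc(-c2ccc3oc(=O)c(-c4ccc(OC)c(OC)c4)c(C)c3c2)cc1` gives 17%, the lowest of the three; its gap to compound 1 and its gap to compound 2 both lie beyond the scatter, so the number for compound 3 stands apart as the lowest of those measured.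

Compound 4 `COc1ccc(-c2c(C)c3cc(-c4ccc(C=O)cc4)ccc3oc2=O)cc1OC` is not yet measured. It differs from compound 3 in one place: formyl in place of methoxy on an aromatic carbon. The change sits on an aromatic carbon of a six-membered aromatic ring of carbon only, para to a large group; cut one bond further out it reads 4-methoxyphenyl to 4-formylphenyl.

For the measured compounds named here, no step between two measured compounds isolates this change, so nothing measured fixes its size. The expectation is a step of a number 7 percentage points higher from compound 3 to compound 4 (within the scatter) that stays within the scatter, with no clear direction, because compound 3 at 17% gives the only anchor. Compound 4 is therefore estimated at 24%, with a range from 5% to 52%.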

Compound 4, a percentage reported as inhibition, at one concentration (the size of the read-out at that concentration, not a potency): 11%
Estimate against measurement, compound 4: 13 percentage points above; low and high end bracket the measured number.
By their numbers in this assay, from the lowest: compounds 4 and 3 (each within the scatter of the next); then compounds 1 and 2 (each within the scatter of the next).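

In this assay, formyl in place of methoxy on this aromatic carbon gives a number 6 percentage points lower from compound 3 to compound 4 (within the scatter) and so the two compounds cannot be told apart at this position. The change keeps the count of heavy atoms and of hydrogen-bond acceptors in the group and adds a double bond outside aromatic rings, and in this one pair that exchange leaves no difference that rises above the scatter. No supporting measurement is available to explain this result.

Going by these compounds, whether an amine or a carboxylic acid on this aromatic carbon, para to a large group, would move the number beyond the scatter remains open. One step on one core also leaves open whether the same exchange of methoxy for formyl would read alike on another core of the series.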